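Fluoro removed from the benzyl ether of compound 1

The source may hold more compounds than are shown below. What is called first, only, known or untested is meant among the compounds shown, and "the series" means these compounds.

Of the compounds shown here, three built on one shared core have been tested in an ADME assay on HEL cells (Homo sapiens) for cytotoxicity, with a stated time of 3 days; a lower number here means that less compound is tolerated, a higher number that more compound is tolerated.

Compound 1 `CCC1(Cc2ccccc2)OS(=O)(=O)C=C1OCc1ccc(F)cc1`: in this assay compound 1 reaches only the limit > 50000 nM.
Compound 2 `CCC1(Cc2ccccc2)OS(=O)(=O)C=C1OCc1ccc(OC)cc1`: in this assay compound 2 likewise reaches only the limit > 200000 nM.
Compound 3 `CCC1(Cc2ccccc2)OS(=O)(=O)C=C1OCc1cccc(Cl)c1`: in this assay compound 3 gives 50000 nM.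

Compound 1 therefore stands at a limit rather than at a number, and among the three values only compound 3 supplies a number; the other two are limits, one at the limit of > 50000 nM in this assay, at which 1 of the 3 values shown sits, and one at the limit of > 200000 nM in this assay, at which 1 of the 3 values shown sits.

Compound 4 `CCC1(Cc2ccccc2)OS(=O)(=O)C=C1OCc1ccccc1` differs from compound 1 by hydrogen in place of fluoro on an aromatic carbon. Three measured steps exist, all at the same position of the benzyl ether: a step that the two limits leave unreadable from compound 1 to compound 2, a number no higher from compound 1 to compound 3 (the limit leaves the size open) and an at least 4.0-fold lower number from compound 2 to compound 3 (0.60 log units; beyond the scatter). None of them removes a group to leave hydrogen, so none bears directly on the step to compound 4, and the two steps that start from compound 1 are open in size. Given the limit of compound 1, the change is expected to leave the number near where compound 1 sits, with a step that the limit leaves unreadable from compound 1 to compound 4, not beyond the scatter. Compound 4 is therefore expected to give about 80000 nM in this assay, between 40000 nM and 200000 nM.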

Compound 4, half-maximal cytotoxic concentration: 200000 nM
For compound 4 the middle estimate is 2.5-fold (0.40 log units) below the measured one; measured number inside the range.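

Compound 4 supplies the second true number at this benzyl ether, and in this assay the exchange of chloro for hydrogen gives a 4.0-fold higher number from compound 3 to compound 4 (0.60 log units; beyond the scatter). Among the compounds shown here, until now the only number at this position belonged to compound 3, so this is the first step here whose size can be read in full, and it shows that this position can move the number by more than the usual scatter. With methoxy at this position the value is a limit, so the data give only a number no higher from compound 2 to compound 4 (the limit leaves the size open). On these data alone, the step to compound 4 from compound 1 cannot be read, so the size of the change from fluoro to hydrogen stays open, with compound 1 standing at a limit: the limit of > 50000 nM in this assay, at which 1 of the 4 values shown sits.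

The compounds shown leave open how the number in this assay would respond to an amine or a carboxylic acid on this aromatic ring, since only hydrogen, fluoro, chloro and methoxy appear there. They also leave open whether the step from compound 3 to compound 4 would hold with any other group on the shared core, such as a longer chain in place of the ethyl group.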